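The source may report more compounds than this note shows. Statements on the series, on what has been measured and on what is new or still open speak of the compounds shown alone.

Measured so far:
compound 1 `CC(C)Sc1n[nH]c(-n2[se]c3ccccc3c2=O)n1` — 34600 nM
compound 2 `O=c1c2ccccc2[se]n1-c1nc(SCc2ccccc2)n[nH]1` — > 50000 nM
compound 3 `CCCSc1n[nH]c(-n2[se]c3ccccc3c2=O)n1` — 30400 nM

In a functional assay on HeLa cells (Homo sapiens) for antiproliferative activity, read by CCK-8 assay, with a stated time of 48 h (on this read-out higher numbers stand for weaker inhibition and lower numbers for stronger inhibition), compound 1 gives 34600 nM, the higher of the two numbers in hand. Compound 3 stands nearest, with a 1.1-fold lower number from compound 1 to compound 3 (0.06 log units; within the scatter). Compound 2 reaches only a limit of this assay, > 50000 nM. The change from compound 1 to compound 2 is benzyl in place of isopropyl on a sulfur, and gives an at least 1.4-fold higher number from compound 1 to compound 2 (0.15 log units; that floor lies within the scatter). Compound 4 `CCSc1n[nH]c(-n2[se]c3ccccc3c2=O)n1` differs from compound 1 by hydrogen in place of methyl on a saturated chain carbon bound to a saturated chain carbon and a sulfur. Within the data shown here, the nearest precedent is the step with propyl in place of isopropyl, which stayed within the scatter, so compound 4 is expected to show no step beyond the scatter, a 1.0-fold higher number from compound 1 to compound 4 (0.00 log units; within the scatter). Compound 4 is therefore estimated at 35000 nM, between 15000 nM and 80000 nM.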

Compound 4, half-maximal inhibitory concentration: 14100 nM
Beside the measured number, compound 4's estimate is 2.5-fold (0.39 log units) above it; the whole stated range lies above it.
By their numbers in this assay, from the lowest: compound 4; then compounds 3 and 1 (each within the scatter of the next). At a limit, above all of these: compound 2.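

In this assay, the group on the sulfur now shows a step beyond the scatter: removing a single methyl gives a 2.5-fold lower number from compound 1 to compound 4 (0.39 log units; beyond the scatter), and from the propyl compound it gives a 2.2-fold lower number from compound 3 to compound 4 (0.33 log units; beyond the scatter). Compound 2 stands only at a limit, > 50000 nM. Read as a floor, methyl in place of phenyl gives an at least 3.5-fold lower number from compound 2 to compound 4 (0.54 log units; beyond the scatter), whereas the earlier steps all stayed within the scatter. From the compounds shown here alone, it remains open whether a methyl or a longer chain such as butyl on the sulfur would lower or raise the number, and what an amine on that chain would do.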